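Fluoro on the benzylamino phenyl: expectation for compound 3

This account rests on a few compounds, and the source may have more. Where it says the series, first, only, none or still open, it means among the compounds named here.

Measured so far in a functional assay on MV4-11 cells (Homo sapiens) for antiproliferative activity, read by CellTiter-Glo, with a stated time of 72 h (on this read-out lower numbers stand for stronger inhibition of growth and higher numbers for weaker inhibition of growth), for this series:
Compound 1 `CNc1nc(-c2cc(N[C@H]3CC[C@H](NCCOC)CC3)ncc2Cl)cs1` gives 530 nM
Compound 2 `COCCN[C@H]1CC[C@H](Nc2cc(-c3csc(NCc4ccccc4)n3)c(Cl)cn2)CC1` gives 330 nM

Compound 2 at 330 nM stands level, within the scatter, with compound 1 at 530 nM on these numbers, so neither can be ranked above the other. The next compound is compound 3 `COCCN[C@H]1CC[C@H](Nc2cc(-c3csc(NCc4ccc(F)cc4)n3)c(Cl)cn2)CC1`, and the change is fluoro in place of hydrogen on an aromatic carbon in the form of fluoro in place of hydrogen on an aromatic carbon, turning benzylamino into (4-fluorobenzyl)amino. For the measured compounds named here, no measured step covers this exact change. Going by the values given here, the one step bearing on it brought in the phenyl that now carries the fluoro, and it reads a 1.6-fold lower number from compound 1 to compound 2 (0.21 log units; within the scatter) for phenyl in place of hydrogen on a saturated chain carbon bound to a nitrogen on an aromatic ring. Among the compounds with values here, with only that small step as a guide, no step beyond the scatter is expected in this assay from this single atom. The expected step is a 1.0-fold lower number from compound 2 to compound 3 (0.01 log units; within the scatter) and no direction can be argued from the data. The estimated value for compound 3 is 320 nM with an expected range from 140 nM to 720 nM in this measurement.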

Compound 3, concentration for 50% growth inhibition: 880 nM
Beside the measured number, compound 3's estimate is 2.8-fold (0.44 log units) below it; the measured number lies above the stated range.
By their numbers in this assay, from the lowest: compounds 2, 1 and 3 (each within the scatter of the next, the first and the last beyond it).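

In this assay, for the compounds shown here, the carbon para to a large group on the six-membered aromatic ring of carbon only does not tolerate substitution without consequence: fluoro in place of hydrogen there gives a 2.7-fold higher number from compound 2 to compound 3 (0.43 log units; beyond the scatter), the first step to lie beyond the scatter, though it is modest. Taken as a whole, 4-fluorophenyl in place of hydrogen on the saturated chain carbon gives a 1.7-fold higher number from compound 1 to compound 3 (0.22 log units; within the scatter), so the complete 4-fluorobenzyl group brings no readable change over the hydrogen it replaces. No available data account for the loss seen with fluoro at this position.

From the compounds shown here alone, it remains open whether this step is specific to fluoro or applies more generally to substitution at this carbon, a question that chloro, methoxy or a nitrile at the same place would help to settle. Also open, going by these compounds, is whether fluoro on another carbon of the same ring, or a longer chain joining the ring to the amine nitrogen, would give a different reading in this assay.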